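The source may hold more compounds than are shown below. What is called first, only, known or untested is meant among the compounds shown, and "the series" means these compounds.

Measured in an ADME assay on HEK293 cells (Homo sapiens) for cytotoxicity, read by MTT assay, with a stated time of 36 h; a higher number here means a weaker inhibitor, a lower number a stronger inhibitor:
- Compound 1 `O=C(c1ccc2c(c1)OCCO2)C1CCN(Cc2coc(-c3ccc(F)cc3)n2)CC1`: > 150 ug/mL (a limit)
- Compound 2 `COc1ccc(-c2nc(CN3CCC(C(=O)c4ccc5c(c4)OCCO5)CC3)co2)cc1`: > 150 ug/mL (a limit)
- Compound 3 `O=C(c1ccc2c(c1)OCCO2)C1CCN(Cc2coc(-c3ccco3)n2)CC1`: > 150 ug/mL (a limit)

None of these entries is a number, and compound 3 stands with the other two at the limit of > 150 ug/mL in this assay, at which 3 of the 3 values shown sit.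

Compound 4 `O=C(c1ccc2c(c1)OCCO2)C1CCN(Cc2coc(-c3ccoc3)n2)CC1` keeps the core of compound 3 and changes one group, with furan-3-yl in place of furan-2-yl on an aromatic carbon, next to the ring nitrogen and next to the ring oxygen: furan-3-yl in place of furan-2-yl on an aromatic carbon.

Among the compounds with values here, two measured steps concern this same place: a step that the two limits leave unreadable from compound 1 to compound 3 and a step that the two limits leave unreadable from compound 2 to compound 3. Neither has a size that can be read, so they offer no measured effect to carry over to compound 4. Even so, three different groups at this place have all ended at the same limit in this assay, so another limit is the likeliest report.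

The expected change is no more than the scatter, in no particular direction: a step that the limit leaves unreadable from compound 3 to compound 4. For compound 4 the estimated value is 200 ug/mL, within an expected range of 120 ug/mL to 400 ug/mL.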

Compound 4, half-maximal inhibitory concentration: > 150 ug/mL
Compound 4: only a limit was reported (the forecaster's own chance of this, stated with the estimate: 85%); the middle value is on the limit's open side.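

In this assay compound 4 gives > 150 ug/mL, which is a limit, so its steps from compound 1, compound 2 and compound 3 cannot be read. The compounds shown leave open whether the group at this place affects cytotoxicity at all: the limit of > 150 ug/mL in this assay, at which 4 of the 4 values shown sit.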